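This account rests on a few compounds, and the source may have more. Where it says the series, first, only, none or still open, it means among the compounds named here.

Measured so far in a functional assay on HT-29 cells (Homo sapiens) for cytotoxicity, read by MTT assay, with a stated time of 72 h; on this read-out lower numbers stand for stronger inhibition and higher numbers for weaker inhibition:
- compound 1 `CN(C)CCn1cnnc1-c1cc(Oc2ccc(NC(=O)N/N=C/c3c(Cl)cccc3Cl)cc2F)ccn1`: 280 nM
- compound 2 `Cn1ncnc1-c1cc(Oc2ccc(NC(=O)N/N=C/c3ccccc3)cc2F)ccn1`: 30200 nM
- compound 3 `CN(C)CCn1cnnc1-c1cc(Oc2ccc(NC(=O)N/N=C/c3ccc(O)c(O)c3)cc2F)ccn1`: 1890 nM

Compound 3 holds the second highest of the three numbers. Among the measured compounds shown here, its nearest neighbour is compound 1, and the only single-place step in the set, a 6.8-fold higher number from compound 1 to compound 3 (0.83 log units; beyond the scatter), runs between them. For the measured compounds named here, compound 2, which differs from compound 3 in more than one place, gives the highest number in this assay; no step is computed for that pair, so only the two values themselves are on hand.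

Compound 4 `CN(C)CCn1cnnc1-c1cc(Oc2ccc(NC(=O)N/N=C/c3ccc(O)cc3O)cc2F)ccn1` is the next compound to be measured. It differs from compound 3 in this way: 2,4-dihydroxyphenyl in place of 3,4-dihydroxyphenyl on a carbon with a double bond to nitrogen

Going by the values given here, the single step that touches the same carbon, a 6.8-fold higher number from compound 1 to compound 3 (0.83 log units; beyond the scatter), swaps one aryl group for a wholly different one and is modest in size. Among the compounds with values here, no measured step moves a hydroxyl from one position of the ring to another, so the bearing of a 6.8-fold higher number from compound 1 to compound 3 (0.83 log units; beyond the scatter) on compound 4 is indirect at best. With the same atoms retained and only their arrangement changed, the expected step from compound 3 to compound 4 is a 1.2-fold lower number from compound 3 to compound 4 (0.07 log units; within the scatter), which is not expected to exceed the scatter in either direction. Compound 4 is therefore estimated at 1600 nM in this assay, with a range of 400 nM to 6500 nM.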

Compound 4, half-maximal inhibitory concentration: 52600 nM
Estimate against measurement, compound 4: 33-fold (1.52 log units) below, and the stated range ends below it.
By their numbers in this assay, from the lowest: compound 1; then compound 3; then compounds 2 and 4 (each within the scatter of the next).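

In this assay the arrangement of the two hydroxyl groups on the aryl ring at this carbon counts, not only their presence: the change to 2,4-dihydroxyphenyl brings a 28-fold higher number from compound 3 to compound 4 (1.44 log units; beyond the scatter) with the same atoms and the same hydrogen-bond donor and acceptor counts. Replacing 2,6-dichlorophenyl with 2,4-dihydroxyphenyl gives a 190-fold higher number from compound 1 to compound 4 (2.27 log units; beyond the scatter) and places compound 1, compound 3 and compound 4 in that order of rising numbers. No evidence on hand accounts for this difference between the two hydroxyl arrangements.

Still open, on these data alone, is how a methoxyphenyl group or a phenyl ring with a single hydroxyl at this carbon would read on the core of compound 3. Also open, as far as these compounds go, is whether the same order of aryl groups holds on the core of compound 2.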